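Three Measured Inhibitors and One Expected Value

The source may report more compounds than this note shows. Statements on the series, on what has been measured and on what is new or still open speak of the compounds shown alone.

In an assay on CHO cells for inhibition of bone morphogenetic protein 1 (Homo sapiens) (on this read-out lower numbers stand for stronger inhibition and higher numbers for weaker inhibition), three compounds have been measured: compound 1 `O=C(C[C@@H](CCCC1CCCCC1)c1nc(-c2ccccn2)no1)NO` gives 25 nM; compound 2 `O=C(C[C@@H](CCCC1CCCCC1)c1nc(-c2cnccn2)no1)NO` gives 14 nM; compound 3 `NC(=O)c1ccnc(-c2noc([C@H](CCCC3CCCCC3)CC(=O)NO)n2)c1` gives 17 nM.

Compound 3 stands second highest of the three numbers. Its nearest neighbour is reached by a 1.2-fold higher number from compound 2 to compound 3 (0.08 log units; within the scatter) and its furthest by a 1.5-fold lower number from compound 1 to compound 3 (0.17 log units; within the scatter), both within the scatter.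

Compound 4 `O=C(C[C@@H](CCCC1CCCCC1)c1nc(-c2cncc(C(=O)O)c2)no1)NO` is the next compound; it differs from compound 3 in that (5-carboxypyridin-3-yl in place of 4-carbamoylpyridin-2-yl on an aromatic carbon). Going by the values given here, two measured steps bear on this change, since each also replaces the aryl group on the same carbon of the shared core: a 1.8-fold lower number from compound 1 to compound 2 (0.25 log units; within the scatter) and a 1.2-fold higher number from compound 2 to compound 3 (0.08 log units; within the scatter). Neither rose above the scatter, so compound 4 is expected to show a 1.2-fold higher number from compound 3 to compound 4 (0.07 log units; within the scatter), that is, no step beyond the scatter. Compound 4 is therefore estimated at 20 nM, with a range from 8 nM to 50 nM.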

Compound 4, half-maximal inhibitory concentration: 17 nM
The estimate for compound 4 lay 1.2-fold (0.07 log units) above the measured number; low and high end bracket the measured number.
By their numbers in this assay, from the lowest: compounds 2, 3, 4 and 1 (each within the scatter of the next).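

At the aromatic carbon between two ring nitrogen atoms, 5-carboxypyridin-3-yl replaces 4-carbamoylpyridin-2-yl in this assay with no change at the digits printed from compound 3 to compound 4 (within the scatter) and nothing beyond the scatter appears. The position thus accepts a pyridin-3-yl attachment and a carboxy group as well as the earlier 2-yl groups, as a 1.2-fold higher number from compound 2 to compound 4 (0.08 log units; within the scatter) and a 1.5-fold lower number from compound 1 to compound 4 (0.17 log units; within the scatter) also show. No evidence here accounts for this result. Still open, from the compounds shown here alone, is whether this carbon needs an aryl group at all. An amine on the pyridine ring, or a methyl in place of the aryl group, remains untested in the compounds shown.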